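Notes on the ring amide nitrogen substituent

The source may hold more compounds than are shown below. What is called first, only, known or untested is meant among the compounds shown, and "the series" means these compounds.

Compound 1 `CCCCCCCCCC[C@H](O)COCCOC[C@@H](O)CCCCCCCCCCCCC1=C[C@H](C)NC1=O` is the parent with an unsubstituted ring amide nitrogen; in a functional assay on B16 cells (Homo sapiens) for cytotoxicity against B16 (Mus musculus), read by MTT assay, with a stated time of 48 h (on this read-out higher numbers stand for weaker inhibition and lower numbers for stronger inhibition), compound 1 gives 35 nM. Compound 2 `CCCCCCCCCC[C@H](O)COCCOC[C@@H](O)CCCCCCCCCCCCC1=C[C@H](C)N(C)C1=O` carries methyl in place of hydrogen on that nitrogen, and in this assay compound 2 gives 13 nM, which is a 2.7-fold lower number from compound 1 to compound 2 (0.43 log units; beyond the scatter). Among the two measured numbers compound 2 therefore holds the lowest, with compound 1 as its only neighbour at the step just given.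

Compound 3 `CCCCCCCCCC[C@H](O)COCCOC[C@@H](O)CCCCCCCCCCCCC1=C[C@H](C)N(CCCNC(=O)C(F)(F)F)C1=O` continues from compound 2 by 2-(((trifluoromethyl)carbonyl)amino)ethyl in place of hydrogen on a saturated chain carbon bound to an amide-type nitrogen in a ring; cut one bond further out, the change reads methyl to 3-(((trifluoromethyl)carbonyl)amino)propyl. Among the compounds with values here, the only measured step that bears on this position is the one from hydrogen to methyl, a 2.7-fold lower number from compound 1 to compound 2 (0.43 log units; beyond the scatter), a modest gain. Within the data shown here, no measured pair shows what a longer chain carrying an amide on this nitrogen does, so the step expected here, a 1.2-fold higher number from compound 2 to compound 3 (0.06 log units; within the scatter), is taken as small and close to the scatter, with a wide range to either side. Compound 3 is accordingly estimated at 15 nM in this assay, with a range from 5 nM to 50 nM.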

Compound 3, half-maximal inhibitory concentration: 995 nM
For compound 3 the middle estimate is 66-fold (1.82 log units) below the measured one; measured number above the stated range.
By their numbers in this assay, from the lowest: compound 2; then compound 1; then compound 3.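

The nitrogen of the ring amide does not accept every substituent alike: in this assay, replacing methyl with 3-(((trifluoromethyl)carbonyl)amino)propyl gives a 77-fold higher number from compound 2 to compound 3 (1.88 log units; beyond the scatter), a large loss that reverses the modest gain from methyl. The same group also ends up well short of the unsubstituted parent, with a 28-fold higher number from compound 1 to compound 3 (1.45 log units; beyond the scatter), so the position shows substituents moving the number in both directions relative to hydrogen, and the gain seen with methyl cannot be extended to this longer group. Nothing at hand bears on the cause of this loss.

The three compounds cannot separate the contribution of the propyl chain from that of its terminal trifluoromethyl carbonyl amide, since the two enter together in one step. A plain propyl group, a propyl chain ending in a free primary amine, and a propyl chain ending in an acetyl amide would each divide that step, while ethyl would show whether anything larger than methyl keeps the lower number.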